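The compounds below may be only part of what the source reports. "The series", "measured", "known", "first", "only" and "open" are said of these compounds alone.

Measured so far in an in vitro functional assay on 1321-N1 cells for agonist activity at P2Y purinoceptor 4 (Homo sapiens), read by scintillation proximity assay and inositol phosphate accumulation; a higher number here means that more compound is needed for the effect, a lower number that less compound is needed:

Compound 1, `Nc1nc(=O)ccn1[C@@H]1O[C@H](COP(=O)(O)OP(=O)(O)O)[C@@H](O)[C@H]1O`, gives only a limit of this assay, >= 100000 nM.
Compound 2, `Nc1nc(=O)ccn1[C@@H]1O[C@H](COP(=O)(O)O)[C@@H](O)[C@H]1O`, gives 4980 nM.
Compound 3, `COc1nc(=O)ccn1[C@@H]1O[C@H](COP(=O)(O)OP(=O)(O)O)[C@@H](O)[C@H]1O`, gives 4490 nM.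

Of the two true numbers, compound 2 has the highest, but its nearest neighbour, compound 3, sits within the usual scatter of it, so the two cannot be told apart. Compound 1 sits at the limit of the assay, (the limit of >= 100000 nM in this assay, at which 1 of the 3 values shown sits), and gives no number. Two changes from compound 1 have been measured: an at least 20-fold lower number from compound 1 to compound 2 (1.30 log units; beyond the scatter), and an at least 22-fold lower number from compound 1 to compound 3 (1.34 log units; beyond the scatter). Both steps lead away from the limit and down to a number, and both are large.

Compound 4, `CCCSc1nc(=O)ccn1[C@@H]1O[C@H](COP(=O)(O)O)[C@@H](O)[C@H]1O`, is not yet measured. It differs from compound 2 in one place: propylsulfanyl in place of amino on an aromatic carbon. The step that bears on it most directly is the one in which methoxy replaced amino on the same aromatic carbon, an at least 22-fold lower number from compound 1 to compound 3 (1.34 log units; beyond the scatter), a large drop in the number needed. Swapping the amino for propylsulfanyl in compound 4 is the same kind of change at the same place, so a lower number in this assay is expected, and it could be a large step. Compound 4 is therefore estimated at 500 nM, most likely between 50 nM and 5000 nM, which would mean a 10-fold lower number from compound 2 to compound 4 (1.00 log units; beyond the scatter).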

Compound 4, half-maximal effective concentration: > 100000 nM
Compound 4: no number, only a limit; the forecaster's own chance of this, stated with the estimate: 5%; middle value at least 200-fold (2.30 log units) from the limit.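

Compound 4 sits at a limit of this assay and gives no number: the limit of > 100000 nM in this assay, at which 1 of the 4 values shown sits. Replacing the amino group on the aromatic carbon between two ring nitrogen atoms therefore does not push the result in one fixed direction: methoxy gave an at least 22-fold lower number from compound 1 to compound 3 (1.34 log units; beyond the scatter), while propylsulfanyl gave an at least 20-fold higher number from compound 2 to compound 4 (1.30 log units; beyond the scatter). The two steps start from different cores, and the drop seen with methoxy did not carry over to propylsulfanyl.

Whether the rise belongs to the propylsulfanyl group itself or depends on the core of compound 2 stays open; among the compounds shown, methoxy appears only on the core of compound 1 and propylsulfanyl only on the core of compound 2. A methylsulfanyl group or a propoxy group on the same aromatic carbon would help separate the effect of the sulfur atom from that of the length of the chain.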